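Swapping furan-3-yl for ethynyl on an inactive nucleoside

This account rests on a few compounds, and the source may have more. Where it says the series, first, only, none or still open, it means among the compounds named here.

- compound 1 `CSc1ncnc2c1c(-c1ccoc1)cn2[C@@H]1O[C@H](CO)[C@@H](O)[C@H]1O`: 3250 nM
- compound 2 `CNc1ncnc2c1c(-c1ccoc1)cn2[C@@H]1O[C@H](CO)[C@@H](O)[C@H]1O`: > 20000 nM (a limit)
- compound 3 `Cc1ncnc2c1c(-c1ccoc1)cn2[C@@H]1O[C@H](CO)[C@@H](O)[C@H]1O`: > 20000 nM (a limit)

In a functional assay on K562 cells (Homo sapiens), read by MTT assay, with a stated time of 72 h (a lower number here means a stronger inhibitor, a higher number a weaker inhibitor), compound 3 gives > 20000 nM, which is a limit and not a number. That value is the limit of > 20000 nM in this assay, at which 2 of the 3 values shown sit.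

Compound 4 `C#Cc1cn([C@@H]2O[C@H](CO)[C@@H](O)[C@H]2O)c2ncnc(C)c12` keeps the methyl group of compound 3 but carries ethynyl in place of furan-3-yl on an aromatic carbon.

Within the data shown here, no measured step changes the furan-3-yl group, so none gives a direct size for this swap. The nearest evidence is the methyl for methylsulfanyl change, which gave an at least 6.1-fold higher number from compound 1 to compound 3 (0.78 log units; beyond the scatter). It shows that a single small group can move the read-out beyond the scatter, so a modest fall in the number is expected, although another limit remains quite possible.

The step expected is an at least 2.0-fold lower number from compound 3 to compound 4 (0.30 log units; that floor lies within the scatter).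

For compound 4 the estimate is 10000 nM, with an expected range of 2500 nM to 20000 nM.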

Compound 4, half-maximal inhibitory concentration: 110 nM
Estimate against measurement, compound 4: 91-fold (1.96 log units) above; the measured number lies below the stated range.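

In this assay, among these compounds, the earlier compounds varied only a different place on the shared core, whereas this change at the aromatic carbon two ring bonds from the ring nitrogen gives an at least 180-fold lower number from compound 3 to compound 4 (2.25 log units; beyond the scatter). The entering ethynyl has 2 heavy atoms and no ring, against 5 heavy atoms and a five-membered aromatic ring in furan-3-yl, so with methyl on the core, a ring at this place is not required for activity. Compound 3 has a limit and not a number, so the true size of this step stays unknown: the limit of > 20000 nM in this assay, at which 2 of the 4 values shown sit.

The compounds shown cannot tell whether the triple bond itself matters or simply the loss of the ring; a nitrile, an ethyl group or a plain hydrogen at this place would separate the two. From the compounds shown here alone, whether ethynyl acts the same way alongside methylsulfanyl or methylamino also remains open.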